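The source may report more compounds than this note shows. Statements on the series, on what has been measured and on what is new or still open speak of the compounds shown alone.

In a functional assay on HCT-116 cells (Homo sapiens) for antiproliferative activity, read by MTT assay, with a stated time of 72 h (a lower number here means a stronger inhibitor, a higher number a weaker inhibitor), two amides on the shared core have been measured. Compound 1 `CC(C)(C)NC(=O)CCc1cccc2c1B(O)OC2`, with tert-butyl on the amide nitrogen, gives > 100000 nM. That value is a limit of the assay and not a number. Among the measured compounds shown here, compound 2 `O=C(CCc1cccc2c1B(O)OC2)Nc1ccc(F)cc1`, which carries 4-fluorophenyl there instead, gives 650 nM, the only true number available so far. The measured change is an at least 150-fold lower number from compound 1 to compound 2 (2.18 log units; beyond the scatter), a large step and well beyond the scatter.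

Compound 3 `O=C(CCc1cccc2c1B(O)OC2)Nc1ccc(Br)cc1` differs from compound 2 at a single site: bromo in place of fluoro on an aromatic carbon. This is bromo in place of fluoro on an aromatic carbon, para to a large group, and the phenyl ring itself stays. For the measured compounds named here, the one measured step, an at least 150-fold lower number from compound 1 to compound 2 (2.18 log units; beyond the scatter), exchanged the whole group on the amide nitrogen, so its size does not carry over to a single halogen exchange. Going by the values given here, no measured pair tests such an exchange, so no step beyond the scatter is expected in this assay, and no direction is favoured. The expected change is a 1.2-fold lower number from compound 2 to compound 3 (0.07 log units; within the scatter). For compound 3 the estimated value is 550 nM, with an expected range of 180 nM to 1700 nM.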

Compound 3, half-maximal inhibitory concentration: 46000 nM
Compound 3: middle estimate off by 84-fold (1.92 log units), on the low side; the measured number lies above the stated range.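

In this assay, among the compounds shown here, the halogen on the phenyl ring proves to matter far more than the single exchange of one atom might suggest: bromo in place of fluoro, on an aromatic carbon para to a large group, gives a 71-fold higher number from compound 2 to compound 3 (1.85 log units; beyond the scatter), a large step like the one produced by exchanging the whole group on the amide nitrogen. A phenyl ring on the amide nitrogen is therefore not enough to reproduce the activity of compound 2, since 4-bromophenyl in place of tert-butyl gives only an at least 2.1-fold lower number from compound 1 to compound 3 (0.33 log units; beyond the scatter). This second step can be read only as a bound, since the value of compound 1 is a limit of the assay and not a number: the limit of > 100000 nM in this assay, at which 1 of the 3 values shown sits.

The compounds shown hold only two halogens at this position, leaving open whether chloro, methoxy or a nitrile there would read like compound 2 or like compound 3, and they do not show why the two differ. As far as these compounds go, it also remains open whether the exchange of fluoro for bromo would have the same effect with a longer chain linking the amide to the shared core.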